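The compounds below may be only part of what the source reports. "The series", "measured", "known", "first", "only" and "open" are said of these compounds alone.

In a functional assay on MV4-11 cells (Homo sapiens) for inhibition, read by resazurin assay, with a stated time of 72 h (a higher number here means a weaker inhibitor of growth, a lower number a stronger inhibitor of growth), the three measured compounds give the following numbers:

Compound 1 `CCn1cc(-c2ccnc(Nc3ccc(OC)cc3OC)n2)c2ccccc21`: 3590 nM
Compound 2 `COc1ccc(N(C)c2nccc(-c3cn(C)c4ccccc34)n2)c(OC)c1`: 2000 nM
Compound 3 `COc1ccc(Nc2nccc(-c3sc(N(C)C)nc3C)n2)c(OC)c1`: 170 nM

Among these three, compound 3 stands lowest, and since a lower number here means stronger growth inhibition, it is the strongest of the set. Its nearest neighbour is compound 2, whose number is higher by an amount that lies beyond the usual scatter, and compound 1 sits further still. Compound 3 is thus the natural starting point for the next compound.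

Compound 4 `COc1ccc(Nc2nccc(-c3sc(SCCCN(C)C)nc3C)n2)c(OC)c1` has not yet been measured in this assay. It differs from compound 3 in one place: (3-(dimethylamino)propyl)sulfanyl in place of dimethylamino on an aromatic carbon. The change keeps the shared core of compound 3 intact and only alters what hangs from that one aromatic carbon of the five-membered ring.

Within the data shown here, no measured pair in this set shows what such a swap does, so the expectation rests on compound 3 alone. The step from compound 3 to compound 4 is expected to be small, within or close to the scatter, with a slight lean toward a lower number, which is a 1.1-fold lower number from compound 3 to compound 4 (0.05 log units; within the scatter). Compound 4 is therefore estimated at 150 nM, with a range from 40 nM to 500 nM.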

Compound 4, concentration for 50% growth inhibition: 370 nM
Compound 4: middle estimate off by 2.5-fold (0.39 log units), on the low side; the measured number falls inside the stated range.
By their numbers in this assay, from the lowest: compound 3; then compound 4; then compounds 2 and 1 (each within the scatter of the next).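

In this assay the swap of dimethylamino for (3-(dimethylamino)propyl)sulfanyl, on the aromatic carbon next to the ring nitrogen and the ring sulfur, gives a 2.2-fold higher number from compound 3 to compound 4 (0.34 log units; beyond the scatter) and so costs some growth inhibition, though the loss is modest. Among these compounds, this is the first sign of how this position responds to change: a group of 7 heavy atoms, which brings in a sulfur and keeps a dimethylamino unit at the end of its chain, can replace one of 3 heavy atoms with only this modest rise in the number. Nothing measured here explains the rise.

This single step changes the link to the ring, the chain length and the group size together, so it cannot show which of these accounts for the rise. Still open, from the compounds shown here alone, is how a shorter chain such as (2-(dimethylamino)ethyl)sulfanyl, the same propyl chain joined through an oxygen or an amine nitrogen, or a chain ending in morpholine or a carboxylic acid would fare at this carbon.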